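A few compounds are considered here, and "the series" means these few. Any claim that something is new, unique, unknown or untested is made for them only; others in the source may bear on it.

Working notes on the series. Compound 1 `COc1ccc(S(=O)(=O)N2CCc3cccc(-c4ccc(F)cc4)c32)cc1` and compound 2 `COc1ccc(S(=O)(=O)N2CCc3cccc(-c4ccc(F)c(F)c4)c32)cc1` share one core and differ only on the pendant aromatic ring. In a functional assay on HT-29 cells (Homo sapiens) for inhibition, with a stated time of 72 h (on this read-out lower numbers stand for stronger inhibition and higher numbers for weaker inhibition), compound 1 gives 85.5 nM, and compound 2 gives 57 nM. For the measured compounds named here, the single measured step, a 1.5-fold lower number from compound 1 to compound 2 (0.18 log units; within the scatter), lies within the scatter, so the two compounds cannot be put in order. Compound 2 stands at the lower of the two numbers, with compound 1 nearest at a gap inside the scatter.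

Compound 3 `COc1ccc(S(=O)(=O)N2CCc3cccc(-c4ccncc4)c32)cc1` is not yet measured. Relative to compound 2 the change is pyridin-4-yl in place of 3,4-difluorophenyl on an aromatic carbon. Going by the values given here, no measured step covers an exchange of this kind: the only step available, a 1.5-fold lower number from compound 1 to compound 2 (0.18 log units; within the scatter), concerns a fluoro in place of hydrogen on the same ring and stayed within the scatter, so it gives no direction for the present change. For compound 3 the expected step is a 2.5-fold higher number from compound 2 to compound 3 (0.39 log units; beyond the scatter), set slightly toward a higher number with a wide range to allow for movement either way. The estimate for compound 3 is 140 nM, with a range from 35 nM to 560 nM.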

Compound 3, half-maximal inhibitory concentration: 87.5 nM
Beside the measured number, compound 3's estimate is 1.6-fold (0.20 log units) above it; the range from low to high includes it.
By their numbers in this assay, from the lowest: compounds 2, 1 and 3 (each within the scatter of the next).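

In this assay, pyridin-4-yl in place of 3,4-difluorophenyl gives a 1.5-fold higher number from compound 2 to compound 3 (0.19 log units; within the scatter), and pyridin-4-yl in place of 4-fluorophenyl gives a 1.0-fold higher number from compound 1 to compound 3 (0.01 log units; within the scatter). The earlier step changed only a fluoro substituent on a ring of carbon only, whereas these two steps replace that ring with a six-membered aromatic ring holding a hetero atom, and neither step can be told apart from repeat-measurement noise, so compounds 1, 2 and 3 cannot be put in order at this position. No supporting data bear on why the exchange leaves the read-out within the scatter.

The compounds shown leave open whether any group on this aromatic carbon moves the number beyond the scatter in either direction, as every step available so far stays within it. They also leave open what happens when the aromatic ring at this place gives way to a different kind of group, such as an amine, a carboxylic acid or a longer chain, and whether a flat read-out would hold for such groups on the shared core.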